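The compounds below may be only part of what the source reports. "The series", "measured", "known", "first", "only" and "open" are said of these compounds alone.

Compound 2 `Cc1cc2c(c(N)nn2C)c(=O)[nH]1` gives 29% in an assay on isolated protein for inhibition of MAP kinase-activated protein kinase 2 (Homo sapiens), read by mobility shift assay, tested at 30 uM (a lower number here means less inhibition, a higher number more inhibition at the concentration tested (going by the name of the read-out)), a number that sits within the scatter of compound 1 `Cc1cc2[nH]nc(N)c2c(=O)[nH]1` at 30% and of compound 3 `Cn1nc(N)c2c(=O)[nH]c(-c3ccccn3)cc21` at 36%, so none of the three can be set apart from the others. The change from compound 2 to compound 4 `Cc1cc2c(c(NS(C)(=O)=O)nn2C)c(=O)[nH]1` is methylsulfonyl in place of hydrogen on a nitrogen on an aromatic ring. For the measured compounds named here, no measured step touches that nitrogen. The two steps known, a number 1 percentage points lower from compound 1 to compound 2 (within the scatter) and a number 7 percentage points higher from compound 2 to compound 3 (within the scatter), both lie within the scatter and concern other positions; the series has so far been flat. No step beyond the scatter is therefore expected in this assay for this change either. The step expected is a number 1 percentage points higher from compound 2 to compound 4 (within the scatter). Compound 4 is estimated at 30%, with a range from 15% to 48%.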

Compound 4, a percentage reported as inhibition, at one concentration (the size of the read-out at that concentration, not a potency): 1%
Compound 4: middle estimate off by 29 percentage points, on the high side; measured number outside the range, below it.
By their numbers in this assay, from the lowest: compound 4; then compounds 2, 1 and 3 (each within the scatter of the next).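

For the compounds shown here, the step of a number 28 percentage points lower from compound 2 to compound 4 (beyond the scatter) is the first to pass the scatter in this assay and marks the nitrogen on an aromatic ring as a place where the number responds, unlike the positions changed earlier. Amino to methanesulfonamido leaves compound 4 at 1% with hardly any inhibition at the concentration tested. Nothing available explains this drop.

Open, as far as these compounds go, is whether the loss belongs to methylsulfonyl itself or to any group on this nitrogen. Acetyl or a plain methyl in the same place would separate the two.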